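Swapping the aryl amide on a shared chromone core

The source may report more compounds than this note shows. Statements on the series, on what has been measured and on what is new or still open speak of the compounds shown alone.

In an assay on isolated protein for inhibition of Rho-associated protein kinase 2 (Homo sapiens), read by scintillation counting, radiometric assay and 33P incorporation, with a stated time of 40 min, in the presence of a further agent that is not named here (a higher number here means a weaker inhibitor, a lower number a stronger inhibitor), compound 1 `CC(C)(C)c1ccc(C(=O)Nc2cccc(NC(=O)COc3ccc4c(=O)ccoc4c3)c2)cc1` gives 34 nM, and compound 2 `O=C(COc1ccc2c(=O)ccoc2c1)Nc1cccc(NC(=O)c2cccc([N+](=O)[O-])c2)c1` gives 41 nM, so compound 2 holds the higher of the two numbers, though the gap to compound 1 lies within the scatter. Compound 3 `Nc1ccc(C(=O)Nc2cccc(NC(=O)COc3ccc4c(=O)ccoc4c3)c2)cc1` differs from compound 2 by 4-aminophenyl in place of 3-nitrophenyl on a carbonyl carbon. Going by the values given here, the one step that bears on this change, a 1.2-fold higher number from compound 1 to compound 2 (0.08 log units; within the scatter), also replaced the aryl group on that carbonyl carbon and stayed within the scatter, so he expects compound 3 to show a step of a 1.0-fold lower number from compound 2 to compound 3 (0.01 log units; within the scatter) in this assay, not beyond the scatter. His estimate for compound 3 is 40 nM, with a range from 15 nM to 110 nM.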

Compound 3, half-maximal inhibitory concentration: 83 nM
The estimate for compound 3 lay 2.1-fold (0.32 log units) below the measured number; measured number inside the range.
By their numbers in this assay, from the lowest: compounds 1 and 2 (each within the scatter of the next); then compound 3.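

In this assay, the aryl group on this carbonyl carbon now makes a difference beyond the scatter: there is a 2.0-fold higher number from compound 2 to compound 3 (0.31 log units; beyond the scatter), and a 2.4-fold higher number from compound 1 to compound 3 (0.39 log units; beyond the scatter). The earlier swap of 3-nitrophenyl for 4-(tert-butyl)phenyl stayed within the scatter, so this position does not treat every aryl group alike, though both new steps are modest. 4-aminophenyl stands apart from the other two groups here.

As far as these compounds go, whether a hydroxyl group or an acetamide in place of the amino group would give a similar number remains open. Nothing measured here explains the steps.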